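Replacing Cyclobutylmethyl with tert-Butyl on the Ring Carbon

The source may report more compounds than this note shows. Statements on the series, on what has been measured and on what is new or still open speak of the compounds shown alone.

Three compounds share one core and differ only in the group on a five-membered aromatic ring with 2 nitrogen. Compound 1 `O=C(O)c1ccccc1-c1ccc(CCc2ncc(CC3CCC3)[nH]2)cc1` gives 7.1 nM in an in vitro functional assay on cells for agonist activity at Bombesin receptor subtype-3 (Mus musculus), read by luminescence and calcium flux (on this read-out lower numbers stand for an effect already at smaller amounts and higher numbers for an effect only at larger amounts of compound), the lowest of the three numbers, though within the scatter of both others. Compound 2 `Cc1ccccc1Cc1cnc(CCc2ccc(-c3ccccc3C(=O)O)cc2)[nH]1` gives 9.3 nM and compound 3 `O=C(O)c1ccccc1-c1ccc(CCc2ncc(Cc3ccccc3F)[nH]2)cc1` gives 9.5 nM. The steps of a 1.3-fold higher number from compound 1 to compound 2 (0.12 log units; within the scatter) and a 1.3-fold higher number from compound 1 to compound 3 (0.13 log units; within the scatter) stay within the scatter, as does a 1.0-fold higher number from compound 2 to compound 3 (0.01 log units; within the scatter). Compound 4 `CC(C)(C)c1cnc(CCc2ccc(-c3ccccc3C(=O)O)cc2)[nH]1` carries tert-butyl in place of cyclobutylmethyl on an aromatic carbon. The measured steps only loosely bear on this change: they swap the group on the saturated chain carbon, whereas here that carbon leaves with the ring. They show the position tolerating varied groups. The step is expected to be a 2.0-fold higher number from compound 1 to compound 4 (0.29 log units; within the scatter). Compound 4 is therefore estimated at 14 nM, within 5 nM to 45 nM.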

Compound 4, half-maximal effective concentration: 2750 nM
The estimate for compound 4 lay 200-fold (2.29 log units) below the measured number; the whole stated range lies below it.
By their numbers in this assay, from the lowest: compounds 1, 2 and 3 (each within the scatter of the next); then compound 4.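

The ring-bearing groups tolerated on this aromatic carbon do not extend to tert-butyl: in this assay, replacing cyclobutylmethyl costs heavily (a 390-fold higher number from compound 1 to compound 4 (2.59 log units; beyond the scatter)). The loss is just as large against the other two groups (a 300-fold higher number from compound 2 to compound 4 (2.47 log units; beyond the scatter); a 290-fold higher number from compound 3 to compound 4 (2.46 log units; beyond the scatter)). Compounds 1, 2 and 3 all keep a saturated chain carbon and a ring in this group, whereas tert-butyl has neither.

Neopentyl, which keeps the chain carbon without a ring, or cyclobutyl set directly on the aromatic carbon, could separate these two differences. Nothing available here explains the loss.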